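Indole substituent variation on the cathepsin S series

The source may hold more compounds than are shown below. What is called first, only, known or untested is meant among the compounds shown, and "the series" means these compounds.

For the measured compounds named here, compound 2 `CS(=O)(=O)N1CCc2c(c(-c3ccc(C(F)(F)F)cc3)nn2CC(O)CN2CCC(c3c[nH]c4ccc(C#N)cc34)CC2)C1` gives 21 nM in an assay on isolated protein for inhibition of cathepsin S (Homo sapiens) (a higher number here means a weaker inhibitor, a lower number a stronger inhibitor), the lowest of the two numbers so far; its nearest neighbour is compound 1 `COc1ccc2[nH]cc(C3CCN(CC(O)Cn4nc(-c5ccc(C(F)(F)F)cc5)c5c4CCN(S(C)(=O)=O)C5)CC3)c2c1`, which in this assay gives 29 nM, within the scatter of compound 2. Going by the values given here, the only step measured at this position, a 1.4-fold lower number from compound 1 to compound 2 (0.14 log units; within the scatter), stays within the scatter. Compound 3 `CCOC(=O)c1ccc2[nH]cc(C3CCN(CC(O)Cn4nc(-c5ccc(C(F)(F)F)cc5)c5c4CCN(S(C)(=O)=O)C5)CC3)c2c1` differs from compound 2 by ethoxycarbonyl in place of cyano on an aromatic carbon. Among the compounds with values here, no measured step covers an ethoxycarbonyl group, so the expectation rests on the single step from compound 1 to compound 2, which shows the substituent at this position tolerating exchange without a shift beyond the scatter. The step from compound 2 to compound 3 in this assay is therefore expected to be about a 1.4-fold higher number from compound 2 to compound 3 (0.15 log units; within the scatter), no direction favoured. Compound 3 is estimated at 30 nM in this assay, with a range from 8 nM to 110 nM.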

Compound 3, half-maximal inhibitory concentration: 27 nM
Beside the measured number, compound 3's estimate is 1.1-fold (0.05 log units) above it; the range from low to high includes it.
By their numbers in this assay, from the lowest: compounds 2, 3 and 1 (each within the scatter of the next).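

Ethoxycarbonyl brings 5 heavy atoms in place of the 2 of cyano, yet the step stays within the scatter in this assay (a 1.3-fold higher number from compound 2 to compound 3 (0.11 log units; within the scatter)). The exchange for methoxy also stays within the scatter (a 1.1-fold lower number from compound 1 to compound 3 (0.03 log units; within the scatter)), so methoxy, cyano and ethoxycarbonyl on this aromatic carbon cannot be ranked, and a larger group with a carbonyl is tolerated here, a point that the step between the two smaller groups could not show. No measured evidence is available to explain this result.

Going by these compounds, it remains open whether a carboxylic acid, an amine or a chain longer than ethoxycarbonyl on this aromatic carbon would also stay within the scatter. All three compounds share the rest of the structure, so it is also unknown whether this tolerance would hold with the trifluoromethyl group replaced by hydrogen.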